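This account rests on a few compounds, and the source may have more. Where it says the series, first, only, none or still open, it means among the compounds named here.

Working notes on the series.

In a functional assay on the whole organism with Rattus norvegicus as the target, at a dose of 100 mg/kg (on this read-out lower numbers stand for less inhibition and higher numbers for more inhibition at the one dose given (going by the name of the read-out)), compound 1, `C/N=C(/NC#N)NCCCn1nc(-c2ccccc2)ccc1=O`, gives 40.5%. Compound 2, `C/N=C(\S)NCCCCCn1nc(-c2ccccc2)ccc1=O`, gives 68.9% in this assay. Among the measured compounds shown here, compound 2 thus stands highest of the two numbers measured so far, its nearest neighbour being compound 1; the one single-point step known, a number 28.4 percentage points higher from compound 1 to compound 2 (beyond the scatter), is modest but beyond the scatter.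

Compound 3, `CC/N=C(/NC#N)NCCCCn1nc(-c2ccccc2)ccc1=O`, is not yet measured. It differs from compound 2 as follows: a group of 8 heavy atoms (4 carbon, 4 nitrogen; no ring) in place of a group of 6 heavy atoms (3 carbon, 2 nitrogen, 1 sulfur; no ring), on a saturated chain carbon, four bonds along the chain from an aromatic nitrogen. For the measured compounds named here, the one measured step bears on it, since the group entering compound 3 matches the type of group that left compound 1, while the group leaving compound 3 matches the type that entered compound 2; a drop is therefore expected because a number 28.4 percentage points higher from compound 1 to compound 2 (beyond the scatter) ran in the opposite direction. The expected step in this assay is a number 23.9 percentage points lower from compound 2 to compound 3 (beyond the scatter). Compound 3 is accordingly estimated to give 45% in this assay, with a range from 25% to 65%.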

Compound 3, a percentage reported as inhibition, in the whole organism at one dose (the size of the read-out at that dose, not a potency): 58.8%
Compound 3: middle estimate off by 13.8 percentage points, on the low side; the range from low to high includes it.
By their numbers in this assay, from the lowest: compound 1; then compound 3; then compound 2.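

At this place, four bonds along the chain from an aromatic nitrogen, putting the group of 8 heavy atoms with its nitrile in place of the sulfur-bearing group of 6 heavy atoms gives a step in this assay of a number 10.1 percentage points lower from compound 2 to compound 3 (beyond the scatter). This runs in the opposite direction to a number 28.4 percentage points higher from compound 1 to compound 2 (beyond the scatter) and is smaller in size, so the sulfur-bearing group leads in both steps, although each step also carries other differences along the chain. The change keeps the count of hydrogen-bond donors and adds one acceptor, but no measurement given here explains the step.

The compounds shown leave open how far the chain and the terminal group each contribute, as no pair isolates a longer chain with the terminal group held fixed. Also open, on these data alone, is how a primary amine or a carboxylic acid at this place would read in this assay.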